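The compounds below may be only part of what the source reports. "The series", "measured", "known", "first", "only" and "open" are said of these compounds alone.

Measured compounds in hand:
compound 1 `COc1cccc(OCCC(C)(C)C)c1C(=O)/C=C/c1ccc(O)cc1`, > 30000 nM
compound 2 `O=C(/C=C/c1ccc(O)cc1)c1c(O)cccc1OCc1ccccc1`, > 30000 nM
compound 3 `CC(C)(C)CCOc1cccc(O)c1C(=O)/C=C/c1ccc(C(=O)O)cc1`, 8450 nM

In a functional assay on ACHN cells (Homo sapiens) for antiproliferative activity, read by sulforhodamine B assay (on this read-out lower numbers stand for stronger inhibition of growth and higher numbers for weaker inhibition of growth), compound 2 gives > 30000 nM, which is a limit of the assay and not a number. Compound 1 likewise reaches only a limit in this assay, > 30000 nM. Thus (the limit of > 30000 nM in this assay, at which 2 of the 3 values shown sit). Among the measured compounds shown here, compound 3 is the one compound with a numbered result, giving 8450 nM in this assay. For the measured compounds named here, compound 2 therefore stands at the limit, and one of the two other values shown is a limit as well; no step between measured compounds is computed here.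

Compound 4 `CC(C)COc1cccc(O)c1C(=O)/C=C/c1ccc(O)cc1` differs from compound 2 by isopropyl in place of phenyl on a saturated chain carbon bound to an oxygen on an aromatic ring. Going by the values given here, no measured step covers this kind of change, and both compounds carrying the hydroxyphenyl-bearing enone, compound 1 and compound 2, sit at the limit. The expected step of a number no higher from compound 2 to compound 4 (the limit leaves the size open) is therefore taken as none beyond the scatter, with the estimate itself resting against the limit. Compound 4 is expected to give about 30000 nM in this assay, within 10000 nM to 100000 nM, most probably reported again only as a limit.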

Compound 4, concentration for 50% growth inhibition: 3290 nM
Estimate against measurement, compound 4: 9.1-fold (0.96 log units) above, and the stated range ends above it.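

In this assay, isopropyl in place of phenyl on a saturated chain carbon bound to an oxygen on an aromatic ring gives an at least 9.1-fold lower number from compound 2 to compound 4 (0.95 log units; beyond the scatter). Among the compounds shown here, this is the first pair that differs in one place, and it shows that the group at this place can decide whether the read-out gives a number or stays at a limit. The step has only a lower bound, and its full size stays open: the limit of > 30000 nM in this assay, at which 2 of the 4 values shown sit.

On these data alone, whether a straight butyl chain or an amine at this place would keep the lower number remains open. Compound 1 and compound 3 each differ from compound 4 in more than one place, so the separate contributions of their other changes cannot be read from these compounds.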